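Aryl variation on a fused hexacyclic core: three measured, one pending

The compounds below may be only part of what the source reports. "The series", "measured", "known", "first", "only" and "open" are said of these compounds alone.

Measured so far:
- compound 1, `Cc1nc2c3ccccc3ccc2c2nc3c(ccc4ccccc43)c(-c3ccccc3Cl)c12`: in a functional assay, with a stated time of 90 s (a higher number here means a weaker inhibitor, a lower number a stronger inhibitor), compound 1 gives 170 ug/mL
- compound 2, `Cc1nc2c3ccccc3ccc2c2nc3c(ccc4ccccc43)c(-c3cc([N+](=O)[O-])ccc3N)c12`: in this assay compound 2 gives 110 ug/mL
- compound 3, `Cc1nc2c3ccccc3ccc2c2nc3c(ccc4ccccc43)c(-c3cccc4ccccc34)c12`: in this assay compound 3 gives 179 ug/mL

Compound 1 stands second highest of the three numbers; its nearest neighbour is compound 3 (a 1.1-fold higher number from compound 1 to compound 3 (0.02 log units; within the scatter)), its furthest compound 2 (a 1.5-fold lower number from compound 1 to compound 2 (0.19 log units; within the scatter)). Both steps lie within the scatter, as does a 1.6-fold higher number from compound 2 to compound 3 (0.21 log units; within the scatter), so the three compounds cannot be ordered.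

Compound 4, `Cc1nc2c3ccccc3ccc2c2nc3c(ccc4ccccc43)c(-c3cc(O)nc4ccccc34)c12`, has not yet been measured. It differs from compound 1 as follows: 2-hydroxyquinolin-4-yl in place of 2-chlorophenyl on an aromatic carbon. The bearing steps are those from compound 1, in which the pendant 2-chlorophenyl was replaced by a 2-amino-5-nitrophenyl (a 1.5-fold lower number from compound 1 to compound 2 (0.19 log units; within the scatter)) or by a naphthalen-1-yl (a 1.1-fold higher number from compound 1 to compound 3 (0.02 log units; within the scatter)). Neither a bicyclic aryl nor one carrying hydrogen-bond donors and acceptors moved the number beyond the scatter. The entering 2-hydroxyquinolin-4-yl combines both features, so for compound 4 no step beyond the scatter is expected in this assay, with at most a modest downward lean in line with compound 2. For compound 4 the estimated value is 140 ug/mL, in the range 70 ug/mL to 280 ug/mL, corresponding to an expected step of a 1.2-fold lower number from compound 1 to compound 4 (0.08 log units; within the scatter).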

Compound 4, half-maximal inhibitory concentration: 148 ug/mL
Compound 4: middle estimate off by 1.1-fold (0.02 log units), on the low side; measured number inside the range.
By their numbers in this assay, from the lowest: compounds 2, 4, 1 and 3 (each within the scatter of the next).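

In this assay, the position opposite the ring nitrogen accepts a 2-hydroxyquinolin-4-yl, which adds a six-membered aromatic ring with a hetero atom and brings hydrogen-bond donor and acceptor counts that 2-chlorophenyl lacks, with no step beyond the scatter (a 1.1-fold lower number from compound 1 to compound 4 (0.06 log units; within the scatter)). The same holds against the other two pendant groups (a 1.2-fold lower number from compound 3 to compound 4 (0.08 log units; within the scatter)) and (a 1.3-fold higher number from compound 2 to compound 4 (0.13 log units; within the scatter)), so all four compounds remain within the scatter of one another and this change gives no basis for ordering them. Nothing available explains this insensitivity.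

Going by these compounds, all four pendant groups are aromatic, so it remains open whether a carboxylic acid, a primary amine or a short alkyl chain on this aromatic carbon would produce a step beyond the scatter. On these data alone, the shared core is constant across these compounds, so the effect of changes to it also remains open.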